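The source may report more compounds than this note shows. Statements on the series, on what has been measured and on what is new or still open speak of the compounds shown alone.

Compound 1 `CCc1cc(C(C)=O)c(O)cc1OCCCCCCC#N` gives 103%.
Compound 2 `CCc1cc(C(C)=O)c(O)cc1OCCCC(C)(C)c1nnn[nH]1` gives 100%.
Compound 3 `CCCc1cc(C(C)=O)c(O)cc1OCCCCCC(=O)O` gives 73%.

In an assay on isolated protein for inhibition of leukotriene B4 receptor 1 (Homo sapiens), tested at 10 uM (on this read-out higher numbers stand for more inhibition at the one concentration tested (going by the name of the read-out) and lower numbers for less inhibition), compound 2 stands second highest of the three numbers. Its nearest neighbour is compound 1, and the step of a number 3 percentage points lower from compound 1 to compound 2 (within the scatter) lies within the scatter; compound 3, the furthest, lies lower by an amount beyond the scatter. The unmeasured compound 4 `CCc1cc(C(C)=O)c(O)cc1OCCCCc1nnn[nH]1` differs from compound 2 by (1H-tetrazol-5-yl)methyl in place of 1-(1H-tetrazol-5-yl)-1-methylethyl on a saturated chain carbon, three bonds along the chain from an oxygen on an aromatic ring. Among the compounds with values here, the one measured step at this position, a number 3 percentage points lower from compound 1 to compound 2 (within the scatter), exchanged the group at the chain end without moving the number beyond the scatter, so for this assay no step beyond the scatter is expected, and the estimated step is a number 3 percentage points lower from compound 2 to compound 4 (within the scatter). Compound 4 is therefore expected to give about 97%, between 85% and 105%.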

Compound 4, a percentage reported as inhibition, at one concentration (the size of the read-out at that concentration, not a potency): 49%
The estimate for compound 4 lay 48 percentage points above the measured number; measured number outside the range, below it.
By their numbers in this assay, from the lowest: compound 4; then compound 3; then compounds 2 and 1 (each within the scatter of the next).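

In this assay, this position proved sensitive to more than the identity of the end group: (1H-tetrazol-5-yl)methyl in place of 1-(1H-tetrazol-5-yl)-1-methylethyl gave a number 51 percentage points lower from compound 2 to compound 4 (beyond the scatter), although both groups carry the same ring. The match between the nitrile and tetrazolyl chain ends seen earlier also failed to hold, with a number 54 percentage points lower from compound 1 to compound 4 (beyond the scatter). Nothing measured here accounts for these drops.

The compounds shown leave open how a single methyl on that chain carbon would read. They also leave open how a carboxylic acid in place of the ring on the chain of compound 4 would read.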